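Thiosemicarbazone series: cytotoxicity on RD cells

The compounds below may be only part of what the source reports. "The series", "measured", "known", "first", "only" and "open" are said of these compounds alone.

Compound 1 `COc1ccc2c(c1)/C(=N/NC(=S)Nc1ccccc1)C(=O)N2`, compound 2 `CNC(=S)N/N=C1\C(=O)Nc2ccccc21` and compound 3 `O=C1/C(=N\NC(=S)Nc2ccccc2)c2ccccc2N1c1ccccc1` share a common core and have all been run in an ADME assay on RD cells (Homo sapiens) for cytotoxicity; on this read-out lower numbers stand for higher toxicity in this test and higher numbers for lower toxicity in this test. In this assay compound 1 gives > 25000 nM, a limit of the assay and not a number. Compound 2 gives > 25000 nM in this assay, again a limit. Compound 3 gives > 25000 nM, also a limit. Compound 2 therefore stands at the limit of > 25000 nM in this assay, at which 3 of the 3 values shown sit, and no order among the three can be drawn. Compound 4 `O=C1Nc2ccccc2/C1=N/NC(=S)Nc1ccccc1` is still to be measured. It differs from compound 2 by phenyl in place of methyl on an amide-type nitrogen. Compound 1 and compound 3, both carrying the anilino group, sit at the same limit as compound 2, so no step beyond the scatter is expected. The expected step is a step that the limit leaves unreadable from compound 2 to compound 4. For compound 4 the estimate is 30000 nM, between 12000 nM and 100000 nM.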

Compound 4, half-maximal cytotoxic concentration: > 25000 nM
Compound 4 gave a limit, no number (the forecaster's own chance of this, stated with the estimate: 85%); the middle value lies beyond the limit too.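

Among the compounds shown here, compound 4 gives > 25000 nM in this assay, a limit and not a number, so no step from compound 1, compound 2 or compound 3 to compound 4 can be read. The compounds shown leave open whether any of them differs from another on this read-out: the limit of > 25000 nM in this assay, at which 4 of the 4 values shown sit.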